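Amide series: para substituent swap on the benzamide ring

The source may report more compounds than this note shows. Statements on the series, on what has been measured and on what is new or still open speak of the compounds shown alone.

Measured so far:
compound 1 `CCOC(=O)c1sc(-c2cccc(NC(=O)c3ccc(C(C)(C)C)cc3)c2)nc1Nc1ccc(N2CCN(C)CC2)cc1` — 4.22%
compound 2 `CN1CCN(c2ccc(Nc3nc(-c4cccc(NC(=O)c5ccc(C(F)(F)F)cc5)c4)sc3C(N)=O)cc2)CC1` — 91.9%
compound 3 `CN1CCN(c2ccc(Nc3nc(-c4cccc(NC(=O)c5ccc(F)cc5)c4)sc3C(N)=O)cc2)CC1` — 95.3%

In a functional assay on Raji cells (Homo sapiens) for antiproliferative activity, read by CCK-8 assay, with a stated time of 72 h, tested at 40 uM (a higher number here means more inhibition at the concentration tested (going by the name of the read-out), a lower number less inhibition), compound 3 gives 95.3%, the highest of the three numbers. Compound 2 stands nearest, a number 3.4 percentage points higher from compound 2 to compound 3 (within the scatter), so the two cannot be ordered. Compound 1 lies far off with 4.22%, a gap well beyond the scatter; compound 1 differs from compound 3 in more than one place, so that gap cannot be assigned to any single change.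

Compound 4 `CN1CCN(c2ccc(Nc3nc(-c4cccc(NC(=O)c5ccc(C(C)(C)C)cc5)c4)sc3C(N)=O)cc2)CC1` is not yet measured. It differs from compound 3 only at one position: tert-butyl in place of fluoro on an aromatic carbon. For the measured compounds named here, the one measured step that bears on this position is the change from trifluoromethyl to fluoro on the same aromatic carbon, which gave a number 3.4 percentage points higher from compound 2 to compound 3 (within the scatter), a step within the scatter. On that basis a second swap at the same carbon is expected to move this assay little, if at all, in either direction. Compound 1 also carries tert-butyl at this carbon, but its low number comes with a second structural difference and so does not directly inform the step.

Compound 4 is therefore estimated at 88% (range 55% to 98%), an expected step of a number 7.3 percentage points lower from compound 3 to compound 4 (within the scatter) that is not expected to exceed the scatter.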

Compound 4, a percentage reported as inhibition, at one concentration (the size of the read-out at that concentration, not a potency): 12.1%
Compound 4: middle estimate off by 75.9 percentage points, on the high side, and the stated range ends above it.
By their numbers in this assay, from the lowest: compounds 1 and 4 (each within the scatter of the next); then compounds 2 and 3 (each within the scatter of the next).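

At this carbon, the step from trifluoromethyl to fluoro had left the read-out in this assay unresolved, with a number 3.4 percentage points higher from compound 2 to compound 3 (within the scatter), but tert-butyl separates sharply from both groups: tert-butyl in place of fluoro gives a number 83.2 percentage points lower from compound 3 to compound 4 (beyond the scatter) and tert-butyl in place of trifluoromethyl gives a number 79.8 percentage points lower from compound 2 to compound 4 (beyond the scatter), so this position is not indifferent to the group it carries. With tert-butyl held at the aromatic carbon, amino in place of ethoxy on the carbonyl carbon gives a number 7.9 percentage points higher from compound 1 to compound 4 (within the scatter), so the carbonyl change does not separate these two compounds, and the low number of compound 1 no longer stands apart from the tert-butyl series member with the amide. Nothing measured here accounts for the loss seen with tert-butyl.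

Where the number falls between trifluoromethyl and tert-butyl remains open, since a methyl, an isopropyl or a methoxy at this carbon would be needed to place it. Also open, as far as these compounds go, is whether ethoxy in place of amino on the carbonyl carbon would matter with fluoro or trifluoromethyl on the aromatic carbon, where the read-out sits high rather than low.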